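A Benzyl Side Chain Returns With an Extra Methyl

The compounds below may be only part of what the source reports. "The series", "measured", "known", "first", "only" and "open" are said of these compounds alone.

Of the compounds shown here, three sharing one core have been tested in a functional assay on HCT-116 cells (Homo sapiens) for cytotoxicity, read by MTT assay, with a stated time of 72 h; on this read-out higher numbers stand for weaker inhibition and lower numbers for stronger inhibition. Compound 1 `O=C(NCc1ccc(F)cc1)c1nc(Br)c2cccnc2c1NCc1ccccc1` carries a benzyl group on the ring nitrogen; in this assay compound 1 gives a value of > 20000 nM, which is a limit of the assay rather than a number. Compound 2 `NCCNc1c(C(=O)NCc2ccc(F)cc2)nc(Br)c2cccnc12` gives > 20000 nM in this assay, again only a limit. Compound 3 `COC(=O)CNc1c(C(=O)NCc2ccc(F)cc2)nc(Br)c2cccnc12` gives > 10000 nM in this assay, which is also a limit. Because all three values sit at the limit of > 10000 nM in this assay, at which 1 of the 3 values shown sits, or (the limit of > 20000 nM in this assay, at which 2 of the 3 values shown sit), the steps among them cannot be sized: from compound 1 to compound 2 the change is a step that the two limits leave unreadable from compound 1 to compound 2, from compound 1 to compound 3 it is a step that the two limits leave unreadable from compound 1 to compound 3, and from compound 2 to compound 3 it is a step that the two limits leave unreadable from compound 2 to compound 3.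

Compound 4 `C[C@H](Nc1c(C(=O)NCc2ccc(F)cc2)nc(Br)c2cccnc12)c1ccccc1` is the next member. The change from compound 3 reads (1-phenylethyl in place of (methoxycarbonyl)methyl on a nitrogen on an aromatic ring). This brings back the aromatic ring of compound 1, with one added methyl on the chain carbon. Nothing measured here points toward a readable gain, so the step from compound 3 to compound 4 is expected to be a step that the limit leaves unreadable from compound 3 to compound 4, most likely ending at another limit. Compound 4 is therefore estimated at 25000 nM, within 8000 nM to 80000 nM.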

Compound 4, half-maximal inhibitory concentration: > 20000 nM
Compound 4: only a limit was reported (the forecaster's own chance of this, stated with the estimate: 75%); the middle value does not contradict the limit.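

In this assay compound 4 gives > 20000 nM, which is a limit and not a number. Its steps from compound 1, compound 2 and compound 3 cannot be read. The four compounds shown leave open whether any group on a nitrogen on an aromatic ring of the shared core gives a readable value in this assay.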